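The source may report more compounds than this note shows. Statements on the series, on what has been measured and on what is new or still open speak of the compounds shown alone.

In a functional assay on MCF7 cells (Homo sapiens) for inhibition, read by fluorescence, with a stated time of 72 h (on this read-out lower numbers stand for stronger inhibition and higher numbers for weaker inhibition), compound 3 (`CC[C@@H](N)COc1nc(NC(=N)N)c2ncn(C(C)C)c2n1`) gives > 100000 nM as its reading, which is a limit and not a number. Compound 3 stands alone there (the limit of > 100000 nM in this assay, at which 1 of the 3 values shown sits) with no measured number of its own.

Among the compounds with values here, the two numbers so far belong to compounds with a hydroxy-bearing amino group on the shared core. Compound 1 (`CC(C)n1cnc2c(NC(=N)N)nc(NCCO)nc21`), with (2-hydroxyethyl)amino, gives 12400 nM as its value, and compound 2 (`CC(C)n1cnc2c(NC(=N)N)nc(NCCCCCCO)nc21`), with (6-hydroxyhexyl)amino, gives 5200 nM as its value. Between them lies a modest change, a 2.4-fold lower number from compound 1 to compound 2 (0.38 log units; beyond the scatter), so the chain difference moved the number little.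

Compound 4 (`CC[C@H](CO)Nc1nc(NC(=N)N)c2ncn(C(C)C)c2n1`) has the same atoms as compound 3, joined differently ((1-(hydroxymethyl)propyl)amino in place of 2-aminobutoxy on an aromatic carbon), with (1-(hydroxymethyl)propyl)amino in place of 2-aminobutoxy on an aromatic carbon between two ring nitrogen atoms.

Within the data shown here, two measured steps bear on this, read in reverse. Replacing the amino group of compound 1 with 2-aminobutoxy gave an at least 8.0-fold higher number from compound 1 to compound 3 (0.90 log units; beyond the scatter), and the same replacement on compound 2 gave an at least 19-fold higher number from compound 2 to compound 3 (1.28 log units; beyond the scatter), a large step.

A large step towards a lower number is therefore expected, bringing compound 4 close to compound 1 and compound 2. The estimated change is an at least 12-fold lower number from compound 3 to compound 4 (1.09 log units; beyond the scatter) in all. For compound 4 the expected value is 8000 nM, with an estimated range from 2500 nM to 30000 nM as its likely span.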

Compound 4, half-maximal inhibitory concentration: 4500 nM
Beside the measured number, compound 4's estimate is 1.8-fold (0.25 log units) above it; the range from low to high includes it.
By their numbers in this assay, from the lowest: compounds 4 and 2 (each within the scatter of the next); then compound 1. At a limit, above all of these: compound 3.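

In this assay, rearranging the same atoms on the aromatic carbon between two ring nitrogen atoms, with (1-(hydroxymethyl)propyl)amino in place of 2-aminobutoxy, gives an at least 22-fold lower number from compound 3 to compound 4 (1.34 log units; beyond the scatter) and so shows that this position responds to how the atoms are joined, not only to which atoms are present. Chain form matters far less once a hydroxy-bearing amino group sits there, as 1-(hydroxymethyl)propyl in place of 6-hydroxyhexyl gives a 1.2-fold lower number from compound 2 to compound 4 (0.06 log units; within the scatter) and ethyl in place of hydrogen on the chain carbon bound to the nitrogen gives only a 2.8-fold lower number from compound 1 to compound 4 (0.44 log units; beyond the scatter) as a modest step. As far as these compounds go, the reading of compound 3 remains a limit and not a number, so the size of the large step stays open on one side: the limit of > 100000 nM in this assay, at which 1 of the 4 values shown sits.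

Compound 3 and compound 4 differ in what is bound to the aromatic carbon and in what the chain carries, so the shown compounds cannot tell which of the two changes accounts for the step. From the compounds shown here alone, a 2-hydroxybutoxy group or a (2-aminobutyl)amino group at this position would separate those two changes, and how a carboxylic acid at the chain end would read also remains open.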